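Ethyl in place of (tert-butyl)carbonyl on compound 3

A few compounds are considered here, and "the series" means these few. Any claim that something is new, unique, unknown or untested is made for them only; others in the source may bear on it.

In a functional assay on DA-3 cells for cytotoxicity against DA-3 cell line (Mus musculus), read by MTT assay (a higher number here means a weaker inhibitor, a lower number a stronger inhibitor), compound 2 (`CC(=O)O[C@@H]1OC(=O)[C@@](C)(C(C)=O)[C@@H]1C`) gives 9000 nM and compound 3 (`CC(=O)[C@]1(C)C(=O)O[C@@H](OC(=O)C(C)(C)C)[C@H]1C`) gives 4000 nM, the lower of the two numeric values. Tert-butyl in place of methyl on a carbonyl carbon accounts for a 2.3-fold lower number from compound 2 to compound 3 (0.35 log units; beyond the scatter), a modest change. Compound 1 (`CCO[C@@H]1OC(=O)[C@](C)(C(C)=O)[C@@H]1C`), which carries ethyl on an oxygen, reads > 50000 nM, and this is a limit of the assay. Compound 4 (`CCO[C@@H]1OC(=O)[C@@](C)(C(C)=O)[C@@H]1C`) differs from compound 3 by ethyl in place of (tert-butyl)carbonyl on an oxygen on a saturated carbon. The modest step seen with compound 3 concerns only the carbonyl group, so the limit of compound 1 is the closer guide, and a larger step towards a higher number is expected in this assay. The expected change is an 8.8-fold higher number from compound 3 to compound 4 (0.94 log units; beyond the scatter). For compound 4 the estimated value is 35000 nM, within a range of 12000 nM to 100000 nM.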

Compound 4, half-maximal inhibitory concentration: > 50000 nM
Compound 4 gave a limit, no number; the forecaster's own chance of this, stated with the estimate: 60%; middle value at least 1.4-fold (0.15 log units) away from the limit.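

On the oxygen on a saturated carbon, ethyl in place of (tert-butyl)carbonyl gives an at least 12-fold higher number from compound 3 to compound 4 (1.09 log units; beyond the scatter), and ethyl in place of acetyl gives an at least 5.5-fold higher number from compound 2 to compound 4 (0.74 log units; beyond the scatter), so in this assay the replacement of either carbonyl group by ethyl weighs more than the change between those two groups. Compound 4 reads > 50000 nM, which is a limit. The step between compound 1 and compound 4 cannot be read, so the drawn configuration shows no effect either way: the fact that compounds 1 and 4 differ only in the configuration as drawn

As far as these compounds go, whether a longer chain on the carbonyl, such as hexanoyl, would read lower than compound 3 stays open. So does what an amine-bearing group on this oxygen would do.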